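From 3,5-dimethylphenyl to 2,5-dimethylphenyl on a sulfonamide nitrogen

The source may report more compounds than this note shows. Statements on the series, on what has been measured and on what is new or still open speak of the compounds shown alone.

In a functional assay on MCF7 cells (Homo sapiens) for antiproliferative activity, read by sulforhodamine B assay, with a stated time of 48 h (on this read-out lower numbers stand for stronger inhibition and higher numbers for weaker inhibition), compound 1 (`CCc1ccccc1NS(=O)(=O)c1ccc(N2CCNC2=O)cc1`) gives 350 nM, compound 2 (`CCc1cccc(NS(=O)(=O)c2ccc(N3CCNC3=O)cc2)c1`) gives 130 nM and compound 3 (`Cc1cc(C)cc(NS(=O)(=O)c2ccc(N3CCNC3=O)cc2)c1`) gives 100 nM. The data show a 3.5-fold lower number from compound 1 to compound 3 (0.54 log units; beyond the scatter) and a 1.3-fold lower number from compound 2 to compound 3 (0.11 log units; within the scatter), so compound 3 is separated from compound 1 but not from compound 2. Compound 4 (`Cc1ccc(C)c(NS(=O)(=O)c2ccc(N3CCNC3=O)cc2)c1`) carries 2,5-dimethylphenyl in place of 3,5-dimethylphenyl on a sulfonamide nitrogen. Going by the values given here, the nearest guide is compound 1, the only measured compound bearing 2-ethylphenyl, with a 2.7-fold lower number from compound 1 to compound 2 (0.43 log units; beyond the scatter) on replacing that group by 3-ethylphenyl. The estimated step in this assay is therefore a 2.2-fold higher number from compound 3 to compound 4 (0.34 log units; beyond the scatter), expected to be modest and towards a higher number. The estimate for compound 4 is 220 nM, with an expected range of 90 nM to 500 nM.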

Compound 4, half-maximal inhibitory concentration: 48 nM
Compound 4: the middle estimate sits 4.6-fold (0.66 log units) above what was measured; measured number outside the range, below it.
By their numbers in this assay, from the lowest: compound 4; then compounds 3 and 2 (each within the scatter of the next); then compound 1.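

In this assay, moving one methyl group on the ring gives a 2.1-fold lower number from compound 3 to compound 4 (0.32 log units; beyond the scatter), so this position responds to the arrangement of the methyl groups and not only to their number. With a 2.7-fold lower number from compound 2 to compound 4 (0.43 log units; beyond the scatter) and a 7.3-fold lower number from compound 1 to compound 4 (0.86 log units; beyond the scatter), compound 4 is the most potent of the four, and the weak result for 2-ethylphenyl in compound 1 does not carry over to 2,5-dimethylphenyl. Nothing given here explains this shift. The compounds shown leave open whether a methoxy group, a chlorine atom or an amine could replace either methyl group of 2,5-dimethylphenyl and keep this potency.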